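Ester to acid on the carbonyl carbon in a CDK8 series

The source may report more compounds than this note shows. Statements on the series, on what has been measured and on what is new or still open speak of the compounds shown alone.

compound 1 `NC(=O)/C=C/c1ccncc1-c1ccc2ccccc2c1` — 10.5 nM
compound 2 `COC(=O)/C=C/c1ccncc1-c1ccc2ccccc2c1` — 40.6 nM
compound 3 `CN1CCN(C(=O)/C=C/c2ccncc2-c2ccc(F)cc2)CC1` — 1210 nM

In an assay on a protein complex for inhibition of CDK8/Cyclin C (Homo sapiens), with a stated time of 1 h (a lower number here means a stronger inhibitor, a higher number a weaker inhibitor), compound 2 gives the second highest of the three numbers. Its nearest neighbour is compound 1, and the step between them, a 3.9-fold higher number from compound 1 to compound 2 (0.59 log units; beyond the scatter), comes from methoxy in place of amino on the carbonyl carbon. Within the data shown here, compound 3 stands furthest away, with a much higher number than compound 2; no single-change step links those two, so only their two values are known.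

Compound 4 `O=C(O)/C=C/c1ccncc1-c1ccc2ccccc2c1` is the next member. Its difference from compound 2 is hydrogen in place of methyl on an oxygen next to a carbonyl group. Among the measured compounds shown here, the only measured step that bears on the carbonyl end of the chain is the one from compound 1 to compound 2, which was of modest size and beyond the scatter. For the measured compounds named here, no measured step removes a methyl from an oxygen, so the direction of this change is not fixed by the data; the earlier step shows only that changes at this carbonyl can move this assay by a modest amount.

Compound 4 is therefore expected to lie close to compound 2, with the step of a 1.5-fold higher number from compound 2 to compound 4 (0.17 log units; within the scatter) estimated to be small relative to the scatter. The estimate for compound 4 is 60 nM, with a range from 15 nM to 250 nM.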

Compound 4, half-maximal inhibitory concentration: 5 nM
For compound 4 the middle estimate is 12-fold (1.08 log units) above the measured one, and the stated range ends above it.
By their numbers in this assay, from the lowest: compound 4; then compound 1; then compound 2; then compound 3.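

In this assay, among these compounds, the change at this oxygen runs opposite to the only earlier step at the carbonyl end: a 3.9-fold higher number from compound 1 to compound 2 (0.59 log units; beyond the scatter) went to a higher number, whereas hydrogen in place of methyl gives an 8.1-fold lower number from compound 2 to compound 4 (0.91 log units; beyond the scatter). Hydroxy in place of amino on the carbonyl carbon gives a 2.1-fold lower number from compound 1 to compound 4 (0.32 log units; beyond the scatter), so on the shared core the three end groups fall in a clear order, each step beyond the scatter: the carboxy of compound 4 has the lowest number, the amide of compound 1 the next, and the methyl ester of compound 2 the highest. Nothing in hand accounts for this order, so the result stands as a description of the series only.

Open, from the compounds shown here alone, is how other groups at this carbonyl carbon would fall in that order, such as an ethyl ester, a methyl amide or a tetrazole in place of the carboxy group. Also open, going by these compounds, is whether the same order holds on the core of compound 3, and whether it survives a saturated chain in place of the 2-carboxyethenyl chain.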